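Cytotoxicity notes on a biaryl amide acid series

The source may hold more compounds than are shown below. What is called first, only, known or untested is meant among the compounds shown, and "the series" means these compounds.

Measured so far in this series:
compound 1 `CC(C)N(Cc1cccc(OCCCCCC(=O)O)c1)C(=O)c1ccc(-c2cccc(N(C)C)c2)cc1` — in an ADME assay on HEK293 cells (Homo sapiens) for cytotoxicity, read by CellTiter-Glo and resazurin assay, with a stated time of 72 h (on this read-out higher numbers stand for an effect only at larger amounts of compound and lower numbers for an effect already at smaller amounts), compound 1 gives > 26000 nM, a limit of the assay.
compound 2 `CC(C)N(Cc1cccc(OCCCCCC(=O)O)c1)C(=O)c1ccc(-c2ccco2)cc1` — in this assay compound 2 gives > 26000 nM, likewise a limit.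
compound 3 `CC(C)N(Cc1cccc(OCCCCCC(=O)O)c1)C(=O)c1ccc(-c2cccc(Oc3ccccc3)c2)cc1` — in this assay compound 3 gives > 18700 nM, again a limit and not a number.

Going by the values given here, compound 3 thus stands at a limit, as do the two other measured compounds; nothing among the three values is a read number, so no compound can be placed relative to another. The next compound in the series, compound 4 `CC(C)N(Cc1cccc(OCCCCCC(=O)O)c1)C(=O)c1ccc(-c2cccc(O)c2)cc1`, differs from compound 3 by hydrogen in place of phenyl on an oxygen on an aromatic ring.

Among the compounds with values here, two measured steps touch this part of the scaffold. The step that the two limits leave unreadable from compound 1 to compound 3 alters the same aromatic position as the new change, and the step that the two limits leave unreadable from compound 1 to compound 2 exchanges the whole outer ring. Neither gives a size, because the limit of > 18700 nM in this assay, at which 1 of the 3 values shown sits, and the limit of > 26000 nM in this assay, at which 2 of the 3 values shown sit, together hold all three values at limits. No direction and no size can therefore be read for the step to compound 4; the expectation is no effect beyond the scatter, most likely another limit.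

For compound 4 the expected value in this assay is 30000 nM, with a range from 10000 nM to 100000 nM. The expected step that the limit leaves unreadable from compound 3 to compound 4 is accordingly one of no readable size.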

Compound 4, half-maximal effective concentration: > 26000 nM
Compound 4 was reported as a limit; the forecaster's own chance of this, stated with the estimate: 85%; the middle value does not contradict the limit.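

In this assay compound 4 gives > 26000 nM, a limit of the assay. Going by these compounds alone, with all four values at limits, no step among compound 1, compound 2, compound 3 and compound 4 can be read. The compounds shown leave open where any of the four reaches its half-maximal effect, and whether the changes on the outer ring shift it at all.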